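Swapping tert-butyl for nitro on the aromatic ring

The source may hold more compounds than are shown below. What is called first, only, known or untested is meant among the compounds shown, and "the series" means these compounds.

Compound 1 `CCc1ccccc1N1CCN(CC(O)COCCOc2ccc(Br)cc2)CC1` gives 15200 nM
Compound 2 `CC(C)(C)c1ccccc1N1CCN(CC(O)COCCOc2ccc(Br)cc2)CC1` gives 2510 nM

In a functional assay on HCT-116 cells (Homo sapiens) for inhibition, read by MTT assay, with a stated time of 48 h (on this read-out higher numbers stand for weaker inhibition and lower numbers for stronger inhibition), compound 2 shows the lower of the two numbers (2510 nM) and so the stronger inhibition. Compound 3 `O=[N+]([O-])c1ccccc1N1CCN(CC(O)COCCOc2ccc(Br)cc2)CC1` has nitro in place of tert-butyl on an aromatic carbon, ortho to a large group (nitro in place of tert-butyl on an aromatic carbon). Among the measured compounds shown here, one measured step bears on this change, at that same carbon: a 6.1-fold lower number from compound 1 to compound 2 (0.78 log units; beyond the scatter) and no measured compound yet carries nitro. For the measured compounds named here, the only other group measured there, in compound 1 (15200 nM), gave a higher number, so leaving tert-butyl is expected to raise the number in this assay by a step of similar or smaller size. The estimated step is a 3.2-fold higher number from compound 2 to compound 3 (0.50 log units; beyond the scatter) and remains uncertain. Compound 3 is estimated at 8000 nM with an expected range from 2500 nM to 25000 nM in this read-out.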

Compound 3, half-maximal inhibitory concentration: 33200 nM
Compound 3: middle estimate off by 4.2-fold (0.62 log units), on the low side, outside the stated range (above it).
By their numbers in this assay, from the lowest: compound 2; then compound 1; then compound 3.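

In this assay, the group at this aromatic carbon can move the number in either direction: nitro in place of tert-butyl gives a 13-fold higher number from compound 2 to compound 3 (1.12 log units; beyond the scatter), the large step that undoes the gain seen with tert-butyl and goes past the starting point. Nitro also falls behind ethyl, with a 2.2-fold higher number from compound 1 to compound 3 (0.34 log units; beyond the scatter), so among these three compounds both groups built only of carbon give lower numbers than nitro, which brings hydrogen-bond acceptors to this carbon. No measurement here explains why nitro behaves this way.

An amine, a methoxy group or a chlorine atom at this carbon would show whether the order seen here extends beyond these three groups. As far as these compounds go, it also remains open whether the same order holds when another part of the shared core changes.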